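Swapping Butyl for 4-Fluorophenyl on a Sulfonyl Sulfur

The source may report more compounds than this note shows. Statements on the series, on what has been measured and on what is new or still open speak of the compounds shown alone.

Of the compounds shown here, three have been tested in a functional assay on Huh-7 cells (Homo sapiens) for cytotoxicity, read by MTT assay, with a stated time of 72 h (a lower number here means that less compound is tolerated, a higher number that more compound is tolerated), and none of them gives an exact number. Compound 1 (`CS(=O)(=O)N1CCC2(CC1)OOC1(CCN(S(C)(=O)=O)CC1)OO2`) shows > 100 ug/mL as a limit of the assay. Compound 2 (`CCCCS(=O)(=O)N1CCC2(CC1)OOC1(CCCCC1)OO2`) stands only at the limit > 100 ug/mL and has no exact number. Compound 3 (`COc1ccc(S(=O)(=O)N2CCC3(CC2)OOC2(CCCC2)OO3)cc1`) shows > 100 ug/mL as a limit too. Compound 4 (`O=S(=O)(c1ccc(F)cc1)N1CCC2(CC1)OOC1(CCCCC1)OO2`) carries 4-fluorophenyl in place of butyl on a sulfonyl sulfur. Within the data shown here, no measured pair gives a step size, so no shift beyond the usual scatter is expected in this assay and the reading may well stay at the limit. The expected change is an at least 1.1-fold lower number from compound 2 to compound 4 (0.04 log units; that floor lies within the scatter) and it stays small. Compound 4 is estimated at 90 ug/mL with an expected range from 35 ug/mL to 150 ug/mL in this read-out.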

Compound 4, half-maximal cytotoxic concentration: > 100 ug/mL
Compound 4 ended at the assay's limit (the forecaster's own chance of this, stated with the estimate: 65%); middle value at least 1.1-fold (0.04 log units) away from the limit.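

No step can be read between compound 2 and compound 4, because both readings are limits: the limit of > 100 ug/mL in this assay, at which 4 of the 4 values shown sit. Left open is the concentration at which any of these compounds would become toxic to the cells in this assay.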